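The source may report more compounds than this note shows. Statements on the series, on what has been measured and on what is new or still open speak of the compounds shown alone.

Measured so far in a functional assay on UACC-257 cells (Homo sapiens) for inhibition, read by sulforhodamine B assay, with a stated time of 48 h, tested at 1 uM; on this read-out lower numbers stand for a stronger effect and higher numbers for a weaker effect at the one concentration tested:

Compound 1 `O=C(Nc1cccc(-n2cc(-c3ccncc3)c(-c3cc(O)cc(Cl)c3)n2)c1)Nc1ccc(Cl)c(C(F)(F)F)c1` gives 58%
Compound 2 `O=C(Nc1cccc(-n2cc(-c3ccncc3)c(-c3cc(O)cc(Cl)c3)n2)c1)Nc1ccc(Cl)c(Cl)c1` gives 92%

Of these two numbers, compound 1 has the lower one, which on this read-out means the stronger effect. Among the compounds with values here, the only measured step available is a number 34 percentage points higher from compound 1 to compound 2 (beyond the scatter), a change on the far ring that carries the urea, and it shows that a single swap of one small group there can move the read-out a long way.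

Compound 3 `COc1cc(Cl)cc(-c2nn(-c3cccc(NC(=O)Nc4ccc(Cl)c(C(F)(F)F)c4)c3)cc2-c2ccncc2)c1` is the unmeasured compound. Compared with compound 1, the change is methyl in place of hydrogen on an oxygen on an aromatic ring, so the phenol of compound 1 becomes a methoxy group while everything else is kept. Within the data shown here, no measured pair among the two compounds above touches this oxygen, so the one step that is known does not bear directly on the change; it only shows how large a swing small changes can produce in this system. Among the measured compounds shown here, with no direct precedent, the expectation for compound 3 is a step of a number 10 percentage points higher from compound 1 to compound 3 (within the scatter), meaning a read-out near that of compound 1 but with wide uncertainty in either direction. Compound 3 is therefore estimated at 68%, expected to lie between 42% and 94%.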

Compound 3, a percentage reported as activity, at one concentration (the size of the read-out at that concentration, not a potency): 83%
Estimate against measurement, compound 3: 15 percentage points below, within the range that was stated.
By their numbers in this assay, from the lowest: compound 1; then compounds 3 and 2 (each within the scatter of the next).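

In this assay, within the data shown here, the change from hydroxy to methoxy on the aromatic ring gives a number 25 percentage points higher from compound 1 to compound 3 (beyond the scatter) and so shows that this oxygen, which no earlier pair touched, is a sensitive place in the molecule. In this one pair the hydroxy goes with the stronger effect, and the methyl that enters adds just 1 heavy atom, so a very small edit here can weaken the read-out beyond the usual scatter, as the swap on the far ring carrying the urea also did. Nothing in the data explains why the read-out moves at this oxygen.

Going by these compounds, with only the hydroxy and the methoxy to compare, it stays open whether the loss follows from removing the hydrogen on the oxygen or from adding the carbon. An amine in place of the hydroxy, which keeps hydrogens at that place, and an ethoxy, which extends the chain on the oxygen, would help separate those two readings.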